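The source may hold more compounds than are shown below. What is called first, only, known or untested is meant among the compounds shown, and "the series" means these compounds.

In a functional assay on the whole organism (strain CD-1) with Mus musculus as the target, with a stated time of 0.5 h (on this read-out lower numbers stand for an effect already at smaller amounts and higher numbers for an effect only at larger amounts of compound), compound 1 `CC1(c2ccccc2)CC(=O)N(CC(=O)N2CCOCC2)C1=O` gives 300 mg/kg. Compound 2 `CC1(c2ccccc2)CC(=O)N(CC(=O)N2CCN(c3ccccc3Cl)CC2)C1=O` shares the same core but carries a 2-chlorophenyl on the ring nitrogen of a six-membered ring with two nitrogens, and in this assay compound 2 is reported as "not active" (no number reported), so no single number marks where it stands; it simply showed no effect at the amounts tried. Compound 3 `CC1(c2ccccc2)CC(=O)N(CC(=O)N2CCN(c3cccc(C(F)(F)F)c3)CC2)C1=O` is the next step from compound 2, with 3-(trifluoromethyl)phenyl in place of 2-chlorophenyl on an amine nitrogen in a ring. Among the measured compounds shown here, no measured step between two compounds of this kind is available, so the size of the change in this assay cannot be read from the data; given that compound 2 has no number, the expectation is at best a weak effect, not beyond the scatter from what compound 1 shows. Compound 3 is expected to give about 300 mg/kg, within 100 mg/kg to 1000 mg/kg, with a fair chance that only a limit is reported.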

Compound 3, minimum effective dose: "not active" (no number reported)
Compound 3 has no reported number here, and the estimate cannot be compared.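

Among the compounds shown here, compound 2 and compound 3 are both reported as not active, without a number, so no step between them can be read. Nothing shown offers an explanation for this result. The compounds shown leave open whether exchanging 2-chlorophenyl for 3-(trifluoromethyl)phenyl changes the effect at all.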